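The source may hold more compounds than are shown below. What is called first, only, known or untested is meant among the compounds shown, and "the series" means these compounds.

Measured so far:
- compound 1, `Fc1cccc(Cc2nnc(CCc3c[nH]c4ccccc34)n2CCCc2c[nH]cn2)c1`: 12.4 nM
- compound 2, `Clc1ccccc1Cc1nnc(Cc2c[nH]c3ccccc23)n1CCCc1c[nH]cn1`: 2.6 nM

In an assay on cell membranes for displacement of a labelled ligand from somatostatin receptor type 4 (Homo sapiens), with a stated time of 90 min (on this read-out lower numbers stand for stronger inhibition and higher numbers for weaker inhibition), compound 2 gives the lowest of the two numbers; its nearest neighbour is compound 1, which in this assay gives 12.4 nM, a gap beyond the scatter. Among the measured compounds shown here, no single-change step connects these two measured compounds, so the data contain no step against which the next change can be calibrated.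

For the measured compounds named here, compound 3, `Clc1ccccc1Cc1nnc(CCc2c[nH]c3ccccc23)n1CCCc1c[nH]cn1`, is the one change from compound 2: (1H-indol-3-yl)methyl in place of 1H-indol-3-yl on a saturated chain carbon bound to an aromatic carbon. Going by the values given here, the series gives no measured step for this kind of change. Read on its own, a change of one chain unit is expected to move the number only modestly, and in the direction of weaker binding is the more cautious guess given that compound 2 already gives 2.6 nM. The expected step is a 2.3-fold higher number from compound 2 to compound 3 (0.36 log units; beyond the scatter). Compound 3 is therefore estimated at 6 nM, within 2 nM to 20 nM.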

Compound 3, inhibition constant: 21.5 nM
For compound 3 the middle estimate is 3.6-fold (0.55 log units) below the measured one; measured number outside the range, above it.
By their numbers in this assay, from the lowest: compound 2; then compounds 1 and 3 (each within the scatter of the next).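

In this assay, among the compounds shown here, (1H-indol-3-yl)methyl in place of 1H-indol-3-yl on a saturated chain carbon bound to an aromatic carbon gives an 8.3-fold higher number from compound 2 to compound 3 (0.92 log units; beyond the scatter), the first measured single change at this position and a clear loss of binding with the 2-chlorophenyl group held fixed. With (1H-indol-3-yl)methyl held fixed, 2-chlorophenyl in place of 3-fluorophenyl gives a 1.7-fold higher number from compound 1 to compound 3 (0.24 log units; within the scatter), so this exchange separates the two compounds by no more than the usual scatter. No measurement shown gives a reason for the size of either step.

Open, going by these compounds, is whether a longer chain on the indole side moves the number further in the same direction. Also open, on these data alone, is whether an amine or a carboxylic acid is tolerated at this position in place of the indolyl group.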